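The compounds below may be only part of what the source reports. "The series", "measured", "known", "first", "only" and "open" are said of these compounds alone.

Measured compounds:
compound 1, `O=S(=O)(NCCCCNCc1ccc(Br)cc1)c1cc(C(F)(F)F)cc(C(F)(F)F)c1`, 1500 nM in a functional assay on MCF7 cells (Homo sapiens) for inhibition, read by MTT assay, with a stated time of 72 h; a higher number here means a weaker inhibitor of growth, a lower number a stronger inhibitor of growth
compound 2, `COc1cccc(CNCCCNS(=O)(=O)c2cc(C(F)(F)F)cc(C(F)(F)F)c2)c1`, 2400 nM in this assay

Compound 2 holds the highest of the two numbers shown, and its nearest neighbour is compound 1: the step of a 1.6-fold higher number from compound 1 to compound 2 (0.20 log units; within the scatter) is within the scatter, so the two compounds cannot be ordered on these data. That step replaced the aryl group on the chain bound to the amine nitrogen, and the change now considered, (4-chloro-3-(trifluoromethyl)phenyl in place of 3-methoxyphenyl on a saturated chain carbon bound to an amine nitrogen), gives compound 3, `O=S(=O)(NCCCNCc1ccc(Cl)c(C(F)(F)F)c1)c1cc(C(F)(F)F)cc(C(F)(F)F)c1`, by another exchange at the same place. Among the measured compounds shown here, the one measured step that bears on it is therefore the step from compound 1 to compound 2, and it stayed within the scatter. Nothing in the data tells whether the entering group will behave differently from the bromine-bearing or methoxy-bearing rings already measured, so no step beyond the scatter is expected in this assay, with at most a slight lean toward a lower number in line with compound 1. Compound 3 is expected to give 1800 nM in this assay, in the range 700 nM to 4500 nM, which amounts to an expected step of a 1.3-fold lower number from compound 2 to compound 3 (0.12 log units; within the scatter).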

Compound 3, concentration for 50% growth inhibition: 3500 nM
For compound 3 the middle estimate is 1.9-fold (0.29 log units) below the measured one; the range from low to high includes it.
By their numbers in this assay, from the lowest: compounds 1, 2 and 3 (each within the scatter of the next, the first and the last beyond it).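

In this assay the exchange of 3-methoxyphenyl for 4-chloro-3-(trifluoromethyl)phenyl on a saturated chain carbon bound to an amine nitrogen gives a 1.5-fold higher number from compound 2 to compound 3 (0.16 log units; within the scatter) and thus leaves the two compounds unordered. Compound 2 and compound 3 share the same chain, so this is the first step shown in which only the aryl group changes, whereas the step from compound 1 to compound 2 altered the chain as well; a ring with 11 heavy atoms, carrying chlorine and trifluoromethyl, in place of one with 8 heavy atoms and a methoxy group, therefore produced no step beyond the scatter at this place. No measurement offered here explains this result or links it to any feature of either ring.

The compounds shown leave open whether a ring bearing a carboxylic acid, a hydroxyl group or a nitrile would give a step beyond the scatter at this place. They also leave open how the chain alone acts, since a 4-bromophenyl group on the chain of compound 2, or a longer chain carrying the 4-chloro-3-(trifluoromethyl)phenyl group, would be needed to separate chain from ring.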